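A few compounds are considered here, and "the series" means these few. Any claim that something is new, unique, unknown or untested is made for them only; others in the source may bear on it.

Two members of the series have been run in an ADME assay on Vero cells (Chlorocebus sabaeus) for cytotoxicity, read by neutral red uptake, tested at 1575 ug/mL; a higher number here means a weaker effect of the compound at the concentration tested, a lower number a stronger effect. Compound 1 `O=C1CSC(c2c(Cl)cccc2Cl)N1CCN1CCCCC1` gives 10% there, and compound 2 `COc1ccc(C2SCC(=O)N2CCN2CCCCC2)cc1` gives 11% in this assay, a value within the scatter of compound 1, so the two numbers show no difference between them. Compound 3 `O=C1CSC(c2ccc([N+](=O)[O-])cc2)N1CCN1CCCCC1` awaits measurement in this assay; it differs from compound 2 by nitro in place of methoxy on an aromatic carbon. Among the compounds with values here, no measured pair carries this change, so there is no measured step to lean on. A step of a number 1 percentage points higher from compound 2 to compound 3 (within the scatter) is expected, none beyond the scatter. Compound 3 is estimated at 12%, within a range of 3% to 26%.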

Compound 3, a percentage reported as activity, at one concentration (the size of the read-out at that concentration, not a potency): 15%
The estimate for compound 3 lay 3 percentage points below the measured number, within the range that was stated.
By their numbers in this assay, from the lowest: compounds 1, 2 and 3 (each within the scatter of the next).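

In this assay, within the data shown here, nitro in place of methoxy on an aromatic carbon, para to a large group, gives a number 4 percentage points higher from compound 2 to compound 3 (within the scatter) and thus provides the first measured step at this position. The two groups cannot be told apart here, so this change shows no effect on the read-out beyond the usual scatter. No measured data bear on the reason for this result.

Still open, as far as these compounds go, is whether an amine or a carboxylic acid on this aromatic carbon would stay within the scatter of compound 2. The same question applies to a longer alkoxy chain in place of methoxy.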